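Lengthening the Nitrile Chain of Compound 3

A few compounds are considered here, and "the series" means these few. Any claim that something is new, unique, unknown or untested is made for them only; others in the source may bear on it.

Measured compounds in an assay on isolated protein for binding affinity to leukotriene B4 receptor 1 (Homo sapiens), tested at 1 uM; a lower number here means less inhibition, a higher number more inhibition at the concentration tested (going by the name of the read-out):
compound 1, `CC(=O)c1cc(CO)c(OCCCCCCC#N)cc1O`, gives 8%;
compound 2, `C=CCc1cc(C(C)=O)c(O)cc1OCC#N`, gives 2%;
compound 3, `C=CCc1cc(C(C)=O)c(O)cc1OCCCCCCC#N`, gives 63%.

Compound 3 holds the highest number of the three: the step of a number 55 percentage points higher from compound 1 to compound 3 (beyond the scatter) and the step of a number 61 percentage points higher from compound 2 to compound 3 (beyond the scatter) are both beyond the scatter. The unmeasured compound 4, `C=CCc1cc(C(C)=O)c(O)cc1OCCCCCCCCCCC#N`, is reached from compound 3 by one change, (4-cyanobutyl in place of cyano on a saturated chain carbon, six bonds along the chain from an oxygen on an aromatic ring). Going by the values given here, the step that bears on this change is the one from compound 2 to compound 3, which also lengthens the chain carrying the nitrile, and it is large: a number 61 percentage points higher from compound 2 to compound 3 (beyond the scatter). Whether a further extension continues that rise, or the number simply holds, the shown data do not tell; only one chain-lengthening step is known, so the expectation rests on it alone. A further modest rise, or none beyond the scatter, is therefore expected for compound 4, as a number 9 percentage points higher from compound 3 to compound 4 (within the scatter). The estimate for compound 4 in this assay is 72%, with a range from 50% to 92%.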

Compound 4, a percentage reported as inhibition, at one concentration (the size of the read-out at that concentration, not a potency): 14%
Beside the measured number, compound 4's estimate is 58 percentage points above it; the whole stated range lies above it.
By their numbers in this assay, from the lowest: compounds 2, 1 and 4 (each within the scatter of the next, the first and the last beyond it); then compound 3.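

In this assay, putting 4-cyanobutyl in place of cyano on a saturated chain carbon, six bonds along the chain from an oxygen on an aromatic ring, gives a number 49 percentage points lower from compound 3 to compound 4 (beyond the scatter). Lengthening the nitrile chain therefore does not act in one direction at this position: the earlier step, a number 61 percentage points higher from compound 2 to compound 3 (beyond the scatter), is followed by a fall beyond the scatter, which leaves compound 3, with its intermediate chain, above both the shorter chain of compound 2 and the longer chain of compound 4. Nothing in the data shown accounts for this reversal.

The compounds shown leave open where along the chain lengths between compound 3 and compound 4 the number drops. They also leave open whether a carboxylic acid or an amine at the chain end, in place of the nitrile, would follow the same course.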